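A few compounds are considered here, and "the series" means these few. Any claim that something is new, unique, unknown or untested is made for them only; others in the source may bear on it.

Measured compounds:
- Compound 1 `CCn1c(C(=O)N[C@@H](C)CO)ccc1C(CC)(CC)c1ccc(OCS(=O)(=O)c2ccccc2)c(C)c1`: 10800 nM
- Compound 2 `CCn1c(C(=O)N[C@H](C)CO)ccc1C(CC)(CC)c1ccc(OCS(=O)(=O)c2ccccc2)c(C)c1`: 10600 nM
- Compound 3 `CCn1c(C(=O)NC2(CO)CC2)ccc1C(CC)(CC)c1ccc(OCS(=O)(=O)c2ccccc2)c(C)c1`: 28800 nM

All three were tested in a functional assay on MCF7 cells (Homo sapiens) for antiproliferative activity, read by MTT assay, with a stated time of 24 h; on this read-out higher numbers stand for weaker inhibition and lower numbers for stronger inhibition. Compound 3 stands highest of the three, and its distance from the other two lies beyond the scatter. Compound 4 `CCn1c(C(=O)N[C@H](CO)CCCO)ccc1C(CC)(CC)c1ccc(OCS(=O)(=O)c2ccccc2)c(C)c1` has not yet been measured. It differs from compound 3 on an amide-type nitrogen: a group of 7 heavy atoms (5 carbon, 2 oxygen; no ring) in place of a group of 5 heavy atoms (4 carbon, 1 oxygen; one three-membered non-aromatic ring of carbon only), on an amide-type nitrogen. The ring leaves, and the group that enters has no ring.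

Within the data shown here, two measured steps bear most directly on this change: a 2.7-fold higher number from compound 1 to compound 3 (0.43 log units; beyond the scatter) and a 2.7-fold higher number from compound 2 to compound 3 (0.43 log units; beyond the scatter). In both, the group with the three-membered ring brought the higher number. Configuration alone changed little: a 1.0-fold lower number from compound 1 to compound 2 (0.01 log units; within the scatter).

A modest move back towards a lower number is therefore expected: a 2.2-fold lower number from compound 3 to compound 4 (0.35 log units; beyond the scatter). Compound 4 is estimated at 13000 nM, with an expected range from 5500 nM to 30000 nM.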

Compound 4, half-maximal inhibitory concentration: 31400 nM
For compound 4 the middle estimate is 2.4-fold (0.38 log units) below the measured one; measured number above the stated range.
By their numbers in this assay, from the lowest: compounds 2 and 1 (each within the scatter of the next); then compounds 3 and 4 (each within the scatter of the next).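

In this assay, putting the ringless group of compound 4 in place of 1-(hydroxymethyl)cyclopropyl on the amide-type nitrogen leaves the number where it stood: a 1.1-fold higher number from compound 3 to compound 4 (0.04 log units; within the scatter). The higher number on this nitrogen therefore does not need the three-membered ring, since the open chain also stands clear of the smaller group, with a 2.9-fold higher number from compound 1 to compound 4 (0.46 log units; beyond the scatter) and a 3.0-fold higher number from compound 2 to compound 4 (0.47 log units; beyond the scatter). Those two steps agree whichever of the pair is the starting point: the fact that compounds 1 and 2 differ only in the configuration as drawn

The compounds shown leave open how an amine or a carboxylic acid in place of a hydroxyl on this chain would read. They also leave open whether any group here gives a clearly lower number than compound 1 and compound 2.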